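Compound 1 to compound 4: a 4-nitrophenyl swap

The source may report more compounds than this note shows. Statements on the series, on what has been measured and on what is new or still open speak of the compounds shown alone.

Measured in a functional assay on NIH3T3 cells (Mus musculus); on this read-out higher numbers stand for an effect only at larger amounts of compound and lower numbers for an effect already at smaller amounts:
Compound 1 `CCC/C=C/C=C/c1cc(C#N)ccc1COC(c1ccc(C#N)cc1)c1cncn1C`: 16.7 nM
Compound 2 `Cn1cncc1C(OCc1ccc(C#N)cc1/C=C/c1ccccn1)c1ccc(C#N)cc1`: 23.1 nM
Compound 3 `CCCCCCC#Cc1cc(C#N)ccc1COC(c1ccc(C#N)cc1)c1cncn1C`: > 0.1 nM

The entry for compound 3 is a limit and not a number. Of the two real numbers, compound 1 and compound 2 lie within the scatter of each other, with a 1.4-fold higher number from compound 1 to compound 2 (0.14 log units; within the scatter). That step put pyridin-2-yl in place of pent-1-en-1-yl at the same place that changes next. Compound 4 `Cn1cncc1C(OCc1ccc(C#N)cc1/C=C/c1ccc([N+](=O)[O-])cc1)c1ccc(C#N)cc1` carries 4-nitrophenyl there instead: 4-nitrophenyl in place of pent-1-en-1-yl on a double-bonded chain carbon bound to a double-bonded chain carbon. For the measured compounds named here, with only this one readable step to go on, no shift beyond the scatter is expected in this assay. The estimate is a 1.2-fold higher number from compound 1 to compound 4 (0.08 log units; within the scatter), which is expected to stay within the scatter. Compound 4 is expected at 20 nM, with an estimated range of 6 nM to 70 nM.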

Compound 4, half-maximal effective concentration: 2.24 nM
Beside the measured number, compound 4's estimate is 8.9-fold (0.95 log units) above it; measured number outside the range, below it.
By their numbers in this assay, from the lowest: compound 4; then compounds 1 and 2 (each within the scatter of the next).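

In this assay the place on a double-bonded chain carbon bound to a double-bonded chain carbon now proves responsive to what it carries: 4-nitrophenyl gives a 7.5-fold lower number from compound 1 to compound 4 (0.87 log units; beyond the scatter) and, set against pyridin-2-yl, a 10-fold lower number from compound 2 to compound 4 (1.01 log units; beyond the scatter), a shift the earlier step there did not show. Compound 2 also carries an aromatic ring at this place and stays within the scatter of compound 1: a ring there is not enough on its own. Nothing shown gives a measured reason for the step.

The entry for compound 3 is a limit, and its steps cannot be read: the limit of > 0.1 nM in this assay, at which 1 of the 4 values shown sits. As far as these compounds go, whether an amine or a carboxylic acid in place of the nitro group would keep the lower number stays open.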